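Moving the Nitro Group: From Compound 3 to Compound 4

The source may hold more compounds than are shown below. What is called first, only, known or untested is meant among the compounds shown, and "the series" means these compounds.

Compound 3 `N=C1S/C(=C\c2ccc(OCc3ccccc3)cc2)C(=O)N1c1cccc([N+](=O)[O-])c1` gives 52.9% in an ADME assay on RAW264.7 cells (Mus musculus) for cytotoxicity, read by MTT assay, with a stated time of 48 h, tested at 50 uM (on this read-out lower numbers stand for less inhibition and higher numbers for more inhibition at the one concentration tested (going by the name of the read-out)), the highest of the three measured numbers. Compound 1 `N=C1S/C(=C\c2ccc(OCc3ccccc3)cc2)C(=O)N1c1ccc(Br)cc1` gives 7.83% and compound 2 `N=C1S/C(=C\c2ccc(OCc3ccccc3)cc2)C(=O)N1c1ccc(F)cc1` gives 10.5%; the step of a number 2.7 percentage points higher from compound 1 to compound 2 (within the scatter) is small, while a number 45.1 percentage points higher from compound 1 to compound 3 (beyond the scatter) and a number 42.4 percentage points higher from compound 2 to compound 3 (beyond the scatter) are both large. Compound 4 `N=C1S/C(=C\c2ccc(OCc3ccccc3)cc2)C(=O)N1c1ccc([N+](=O)[O-])cc1` differs from compound 3 only in where the nitro group sits: 4-nitrophenyl in place of 3-nitrophenyl on an amide-type nitrogen in a ring. Going by the values given here, no measured step moves a nitro group from one position to another; the large steps into compound 3 concern a nitrophenyl replacing a halophenyl, not a change of position, so they give only a loose guide. The expectation for compound 4 is a small step of a number 7.9 percentage points lower from compound 3 to compound 4 (within the scatter), with compound 4 estimated at 45%, between 15% and 70%.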

Compound 4, a percentage reported as inhibition, at one concentration (the size of the read-out at that concentration, not a potency): 17.3%
Beside the measured number, compound 4's estimate is 27.7 percentage points above it; the range from low to high includes it.
By their numbers in this assay, from the lowest: compounds 1, 2 and 4 (each within the scatter of the next); then compound 3.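

Where the nitro group sits on the phenyl ring attached to the ring nitrogen matters: in this assay, moving it alone gives a number 35.6 percentage points lower from compound 3 to compound 4 (beyond the scatter). A nitro group as such therefore does not bring the higher number, since 4-nitrophenyl stays with the halophenyl compounds, at a number 6.8 percentage points higher from compound 2 to compound 4 (within the scatter) and a number 9.5 percentage points higher from compound 1 to compound 4 (within the scatter); among these compounds, only 3-nitrophenyl stands apart. No evidence here explains this difference between the two positions. Going by these compounds, it remains open whether an amine or a carboxylic acid in place of the nitro group of compound 3 would keep its high number.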